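Bromo for Ethoxy on a Weakly Active Core

This account rests on a few compounds, and the source may have more. Where it says the series, first, only, none or still open, it means among the compounds named here.

Compound 1 `CCOc1ccc(NC2=CC(=O)c3c(nc4n3[C@H]3OC[C@@H](O)[C@H]3OC4)C2=O)cc1` carries a 4-ethoxyphenyl group on an amine nitrogen of the shared core. In a functional assay on MCF7 cells (Homo sapiens) for inhibition, read by sulforhodamine B assay (a lower number here means a stronger inhibitor, a higher number a weaker inhibitor), compound 1 gives > 4000 nM, which is a limit of the assay and not a number. Compound 2 `O=C1C=C(Nc2cccc(Cl)c2)C(=O)c2c1nc1n2[C@H]2OC[C@@H](O)[C@H]2OC1` gives 4720 nM. Compound 3 `O=C1C=C(NC2CCCC2)C(=O)c2c1nc1n2[C@H]2OC[C@@H](O)[C@H]2OC1` gives > 16000 nM, again a limit of the assay rather than a number. Going by the values given here, the only step measured in one place, an at least 3.3-fold higher number from compound 2 to compound 3 (0.53 log units; beyond the scatter), concerns a change on the amine nitrogen, not on the aromatic ring, so it does not bear directly on the change now considered. Compound 4 `O=C1C(Nc2ccc(Br)cc2)=CC(=O)c2c1nc1n2[C@H]2OC[C@@H](O)[C@H]2OC1` differs from compound 1 as follows: bromo in place of ethoxy on an aromatic carbon. Among the compounds with values here, no measured step tests this kind of swap. Within the data shown here, all three values recorded so far sit at or near the weak end of this assay, and compound 2, the one compound with a number, is also a weak inhibitor. Compound 4 is therefore expected to stay in the same weak range, around 5000 nM, between 2000 nM and 16000 nM. The expected step that the limit leaves unreadable from compound 1 to compound 4 thus amounts to no clear shift beyond the scatter.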

Compound 4, half-maximal inhibitory concentration: 4330 nM
The estimate for compound 4 lay 1.2-fold (0.06 log units) above the measured number, and the stated range covers the measured number.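

The step from compound 1 to compound 4 cannot be read, because the result for compound 1 is a limit of the assay and not a number: the limit of > 4000 nM in this assay, at which 1 of the 4 values shown sits.

The compounds shown leave open how bromo and ethoxy compare at this place on the shared core.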